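Unspecified ring stereocentre in the fluorophenyl analogue of compound 1

This account rests on a few compounds, and the source may have more. Where it says the series, first, only, none or still open, it means among the compounds named here.

Compound 1, `COC(=O)CCNC(=O)[C@@H]1OP(=O)(Oc2ccc(F)cc2)OCC1(C)C`: in an ADME assay on blood (Homo sapiens) for pharmacokinetics (a lower number here means that the compound disappears faster, a higher number that the compound lasts longer), compound 1 gives > 1 h, which is a limit of the assay.
Compound 2, `COC(=O)CCNC(=O)[C@@H]1O[P@@](=O)(OCOC(=O)c2scnc2C(C)(C)C)OCC1(C)C`: in this assay compound 2 gives > 1 h, again a limit.
Compound 3, `COC(=O)CCNC(=O)[C@@H]1O[P@](=O)(OCOC(=O)c2scnc2C(C)(C)C)OCC1(C)C`: in this assay compound 3 gives 0.44 h.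

Compound 1 thus stands at the limit, together with compound 2 (the limit of > 1 h in this assay, at which 2 of the 3 values shown sit); only compound 3 carries a number. Compound 4, `COC(=O)CCNC(=O)C1OP(=O)(Oc2ccc(F)cc2)OCC1(C)C`, differs from compound 1 as follows: the two compounds have the same atoms and bonds; at least one stereo element is drawn with a configuration in one of them and without one in the other: 1 of 2 stereo elements differ; a stereocentre at a saturated ring carbon is drawn R in compound 1 and without a configuration in compound 4. Among the measured compounds shown here, the one measured step that concerns configuration is an at least 2.2-fold lower number from compound 2 to compound 3 (0.35 log units; beyond the scatter), resting on (the fact that compounds 2 and 3 differ only in the configuration as drawn); that step sits at the phosphorus, whereas the change here removes the drawn configuration at the ring carbon, so it bears on it only loosely. A step within the scatter is expected, a number no higher from compound 1 to compound 4 (the limit leaves the size open). Compound 4 is therefore estimated at 1 h, between 0.5 h and 2 h.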

Compound 4, half-life: > 1 h
Compound 4 gave a limit, no number; the forecaster's own chance of this, stated with the estimate: 60%; the middle value sits exactly at the limit.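

Compound 1 and compound 4 both stand at the limit of this assay, so no step can be read between them. The compounds shown leave open whether the configuration drawn at the saturated ring carbon changes the half-life at all.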